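Notes on the aryl swap at the saturated ring carbon

This account rests on a few compounds, and the source may have more. Where it says the series, first, only, none or still open, it means among the compounds named here.

Compound 1 `O=CCN1N=C(c2ccc3ccccc3c2)CC1c1ccccc1` gives 10000 nM in a functional assay on IMR-32 cells (Homo sapiens) for cytotoxicity, read by sulforhodamine B assay, with a stated time of 48 h; a lower number here means a stronger inhibitor, a higher number a weaker inhibitor. Among the measured compounds shown here, compound 2 `O=CCN1N=C(c2ccc3ccccc3c2)CC1c1cccc([N+](=O)[O-])c1` gives 3280 nM and compound 3 `O=CCN1N=C(c2ccc3ccccc3c2)CC1c1ccccc1[N+](=O)[O-]` gives 3360 nM; the step of a 3.0-fold lower number from compound 1 to compound 2 (0.48 log units; beyond the scatter) and the step of a 3.0-fold lower number from compound 1 to compound 3 (0.47 log units; beyond the scatter) both lie beyond the scatter, while a 1.0-fold higher number from compound 2 to compound 3 (0.01 log units; within the scatter) does not, so compound 3 sits together with compound 2 and apart from compound 1 on the numbers so far. Compound 4 `O=CCN1N=C(c2ccc3ccccc3c2)CC1c1cccc(Cl)c1Cl` carries 2,3-dichlorophenyl in place of 2-nitrophenyl on a saturated ring carbon. For the measured compounds named here, no measured step involves a chlorine, so only the gain seen on substituting the phenyl bears on this change. A substituted phenyl is expected to keep that gain, hence the estimated step of a 1.2-fold lower number from compound 3 to compound 4 (0.08 log units; within the scatter) is expected to stay within the scatter. Compound 4 is therefore estimated at 2800 nM, between 900 nM and 9000 nM.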

Compound 4, half-maximal inhibitory concentration: 16900 nM
Estimate against measurement, compound 4: 6.0-fold (0.78 log units) below; the measured number lies above the stated range.
By their numbers in this assay, from the lowest: compounds 2 and 3 (each within the scatter of the next); then compounds 1 and 4 (each within the scatter of the next).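

At the saturated ring carbon, a substituted phenyl does not keep the gain by itself: 2,3-dichlorophenyl gives a 5.0-fold higher number from compound 3 to compound 4 (0.70 log units; beyond the scatter) and a 5.2-fold higher number from compound 2 to compound 4 (0.71 log units; beyond the scatter) in this assay against the nitrophenyl compounds. With a 1.7-fold higher number from compound 1 to compound 4 (0.23 log units; within the scatter) as its step from the plain phenyl, compound 4 sits with compound 1 and apart from compound 2 and compound 3. Nothing measured here explains the split between nitro and chlorine substituents.

As far as these compounds go, it remains open whether a single chlorine would side with compound 4, and whether an amine on the phenyl would side with the nitro compounds.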